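The source may report more compounds than this note shows. Statements on the series, on what has been measured and on what is new or still open speak of the compounds shown alone.

Working notes on the series. In an assay on isolated protein for antagonist activity at prostaglandin E2 receptor EP1 subtype (Homo sapiens), read by reporter gene assay (a lower number here means a stronger inhibitor, a higher number a weaker inhibitor), compound 2 `O=C(O)c1csc(-n2nc(-c3ccccc3)c3ccc(F)cc32)n1` gives 2 nM, the lowest of the two numbers recorded. Compound 1 `O=C(O)c1csc(-n2nc(-c3ccccc3)c3c2CCCC3)n1` gives 16 nM in this assay, a higher number that lies beyond the usual scatter; the two compounds differ in more than one place, so only their two values are stated here.

Compound 3 `Nc1ccc2c(-c3ccccc3)nn(-c3nc(C(=O)O)cs3)c2c1` is the next candidate for this assay. It differs from compound 2 by amino in place of fluoro on an aromatic carbon. Going by the values given here, no measured pair in the set isolates this kind of exchange, so the expectation rests on compound 2 alone, with broad uncertainty. The step expected in this assay is a 3.0-fold higher number from compound 2 to compound 3 (0.48 log units; beyond the scatter), a modest move toward a higher number, close to the edge of the scatter rather than clearly beyond it. For compound 3 the estimated value in this assay is 6 nM, with a range from 1.5 nM to 25 nM.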

Compound 3, half-maximal inhibitory concentration: 19 nM
Compound 3: middle estimate off by 3.2-fold (0.50 log units), on the low side; the range from low to high includes it.
By their numbers in this assay, from the lowest: compound 2; then compounds 1 and 3 (each within the scatter of the next).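

In this assay, going by these compounds alone, amino in place of fluoro is the first exchange that can be read at a single place, and it gives a 9.5-fold higher number from compound 2 to compound 3 (0.98 log units; beyond the scatter) on this aromatic carbon. The position is therefore sensitive to the group it carries: of these two groups, fluoro gives the lower number, and the step lies beyond the scatter. Nothing at hand accounts for the size or direction of this step.

This single pair leaves open how other groups at the same carbon would compare, such as chloro, hydroxyl, methoxy or an acetamide built on the amino group. It also leaves open whether the exchange would give a similar step if the phenyl group or the carboxylic acid were replaced.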